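The source may report more compounds than this note shows. Statements on the series, on what has been measured and on what is new or still open speak of the compounds shown alone.

Measured so far:
- Compound 1, `O=C(NNc1ccccc1Cl)c1cccc(NS(=O)(=O)c2cnc(O)nc2O)c1`: 3350 nM
- Compound 2, `O=C(NNC(=O)c1ccccc1Cl)c1ccc(NS(=O)(=O)c2cnc(O)nc2O)cc1`: 5220 nM

Two compounds carry numbers in a functional assay on OVCAR-3 cells (Homo sapiens) for antiproliferative activity, read by MTT assay, with a stated time of 24 h; a higher number here means a weaker inhibitor, a lower number a stronger inhibitor. Compound 1 gives 3350 nM in this assay, and compound 2 gives 5220 nM. The gap between the two is within the usual scatter, so the two compounds cannot be told apart on these data, and compound 1 simply serves as the starting point of the present step.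

Compound 3, `Cc1ccc(C(=O)NNC(=O)c2cccc(NS(=O)(=O)c3cnc(O)nc3O)c2)cc1`, is not yet measured in this assay. Relative to compound 1 the change is (4-methylphenyl)carbonyl in place of 2-chlorophenyl on an amine nitrogen. For the measured compounds named here, no step between measured compounds is available to calibrate this change; the closest point of reference is compound 2, whose value 5220 nM sits within the scatter of compound 1, and compound 2 shares with compound 3 the carbonyl on the second amine nitrogen.

On that basis the step from compound 1 to compound 3 is expected to be small, a 1.3-fold higher number from compound 1 to compound 3 (0.13 log units; within the scatter), with no direction beyond the scatter claimed. Compound 3 is therefore estimated at 4500 nM in this assay, with an expected range from 2000 nM to 10000 nM.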

Compound 3, half-maximal inhibitory concentration: > 20000 nM
Compound 3: no number, only a limit (the forecaster's own chance of this, stated with the estimate: 5%); middle value at least 4.4-fold (0.64 log units) from the limit.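

In this assay, compound 3 reads > 20000 nM, which is a limit of the assay and not a number. Placing (4-methylphenyl)carbonyl in place of 2-chlorophenyl on this amine nitrogen gives an at least 5.9-fold higher number from compound 1 to compound 3 (0.77 log units; beyond the scatter), so the position is not indifferent to the group it carries, something the earlier compounds, with no step between them, could not show. The size of the step has only a lower bound, and its true extent cannot be read from this result: the limit of > 20000 nM in this assay, at which 1 of the 3 values shown sits.

This single step changes several features at once, so it leaves open whether the loss goes with the added carbonyl, with the loss of the chlorine, or with the methyl group. A 4-methylphenyl group without the carbonyl, a 2-chlorophenylcarbonyl group or a small acetyl group on this same amine nitrogen of the core of compound 1 would separate these features, and a result for any of them remains to be seen in this series.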